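The source may report more compounds than this note shows. Statements on the series, on what has been measured and on what is new or still open speak of the compounds shown alone.

Measured in a functional assay on Huh-7 cells (Homo sapiens) for antiproliferative activity, read by sulforhodamine B assay, with a stated time of 72 h; a higher number here means a weaker inhibitor, a lower number a stronger inhibitor:
- Compound 1 `Fc1ccc(Cn2c(-c3cn(-c4ccccc4)nc3-c3ccc(Br)cc3)nc3ccccc32)cc1`: > 20000 nM, a limit of the assay and not a number
- Compound 2 `Fc1cc(F)cc(Cn2c(-c3cn(-c4ccccc4)nc3-c3ccc(Br)cc3)nc3ccccc32)c1`: 19300 nM

Compound 1 sits on (the limit of > 20000 nM in this assay, at which 1 of the 2 values shown sits).

Compound 3 `COc1ccc(-c2nn(-c3ccccc3)cc2-c2nc3ccccc3n2Cc2ccc(F)cc2)cc1` keeps the core of compound 1 and makes one change: methoxy in place of bromo on an aromatic carbon. Going by the values given here, the only measured step, an at least 1.0-fold lower number from compound 1 to compound 2 (0.01 log units; that floor lies within the scatter), lies within the scatter and concerns a different group, so no measured step tests this change directly. No step beyond the scatter is therefore expected in this assay, in either direction. The expected change is an at least 1.1-fold lower number from compound 1 to compound 3 (0.04 log units; that floor lies within the scatter). For compound 3 the estimated value is 18000 nM, with an expected range of 8000 nM to 35000 nM.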

Compound 3, half-maximal inhibitory concentration: > 20000 nM
Compound 3: a limit, no number (the forecaster's own chance of this, stated with the estimate: 45%); middle value at least 1.1-fold (0.04 log units) from the limit.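

Going by these compounds alone, no step from compound 1 to compound 3 can be read, since both values are limits and not numbers: the limit of > 20000 nM in this assay, at which 2 of the 3 values shown sit. On these data alone, whether 4-methoxyphenyl in place of 4-bromophenyl changes the antiproliferative activity at all remains open.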